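Saturating the Alkynyl Linker of Compound 1

This account rests on a few compounds, and the source may have more. Where it says the series, first, only, none or still open, it means among the compounds named here.

Measured compounds:
compound 1, `CNC(=O)C#Cc1ccc(NC(=O)Nc2ccc(Cl)c(C(F)(F)F)c2)cc1` — 26400 nM
compound 2, `CC(NC(=O)C#Cc1ccc(NC(=O)Nc2ccc(Cl)c(C(F)(F)F)c2)cc1)c1ccccc1` — 12800 nM

Within the data shown here, in a functional assay on MX1 cells (Homo sapiens) for inhibition, read by MTT assay, with a stated time of 120 h (a lower number here means a stronger inhibitor, a higher number a weaker inhibitor), compound 1 stands at the highest of the two numbers; its only neighbour is compound 2, and the single measured step, a 2.1-fold lower number from compound 1 to compound 2 (0.31 log units; beyond the scatter), is modest and concerns the substituent on the amide-type nitrogen rather than the linker to the aromatic ring. Compound 3, `CNC(=O)CCc1ccc(NC(=O)Nc2ccc(Cl)c(C(F)(F)F)c2)cc1`, keeps the methyl on that nitrogen and instead alters the linker: 2-(methylcarbamoyl)ethyl in place of 2-(methylcarbamoyl)ethynyl on an aromatic carbon. Among the measured compounds shown here, no measured step bears on this kind of change, so the data give no direction for it. The expectation for compound 3 is therefore a number close to that of compound 1, with the step of a 1.0-fold lower number from compound 1 to compound 3 (0.01 log units; within the scatter) expected to stay within the usual scatter. Compound 3 is estimated at 26000 nM, with a range from 8000 nM to 85000 nM.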

Compound 3, half-maximal inhibitory concentration: 20400 nM
The estimate for compound 3 lay 1.3-fold (0.11 log units) above the measured number, within the range that was stated.
By their numbers in this assay, from the lowest: compounds 2, 3 and 1 (each within the scatter of the next, the first and the last beyond it).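

Among these compounds, the linker itself is now tested for the first time: in this assay, putting 2-(methylcarbamoyl)ethyl in place of 2-(methylcarbamoyl)ethynyl on the aromatic carbon gives a 1.3-fold lower number from compound 1 to compound 3 (0.11 log units; within the scatter). The triple bond can therefore be removed from compound 1 without moving the number beyond the scatter, whereas the earlier step had concerned only the substituent on the amide-type nitrogen. Nothing at hand accounts for this result.

As far as these compounds go, it remains open whether the 1-phenylethyl group of compound 2 would give a similar step on the saturated linker of compound 3. Also open, from the compounds shown here alone, is how this position would respond to a longer chain, or to a carboxylic acid or an amine in place of the methyl amide.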